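A few compounds are considered here, and "the series" means these few. Any claim that something is new, unique, unknown or untested is made for them only; others in the source may bear on it.

Three esters built on a shared core have been measured. Compound 1 `O=C(OCc1ccccc1Cl)c1cccc(=O)[nH]1` gives, in an assay on isolated protein for inhibition of matrix metalloproteinase-9 (Homo sapiens) (on this read-out higher numbers stand for weaker inhibition and lower numbers for stronger inhibition), 81000 nM. Compound 2 `O=C(OC/C=C/c1ccccc1)c1cccc(=O)[nH]1` gives in this assay 73000 nM. Compound 3 `Cc1ccc(COC(=O)c2cccc(=O)[nH]2)cc1` gives in this assay 68000 nM. On these numbers compound 3 carries the lowest value of the three, yet its gap to compound 2 and its gap to compound 1 both sit within the scatter of repeated measurements, so the three compounds cannot be told apart, and none of them can be called the strongest or the weakest.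

Compound 4 `O=C(OCc1ccc(C(F)(F)F)cc1)c1cccc(=O)[nH]1` differs from compound 3 in one place: trifluoromethyl in place of methyl on an aromatic carbon. Within the data shown here, no pair of measured compounds shares a single change, so there is no measured step to lean on. The three measured values all cluster close together, which gives no hint of a sizeable move in either direction. The step from compound 3 to compound 4 in this assay is therefore expected to be a 1.0-fold higher number from compound 3 to compound 4 (0.01 log units; within the scatter), that is, nothing beyond the scatter. Compound 4 is estimated to give 70000 nM in this assay, within a range from 30000 nM to 160000 nM.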

Compound 4, half-maximal inhibitory concentration: 101000 nM
Beside the measured number, compound 4's estimate is 1.4-fold (0.16 log units) below it, and the stated range covers the measured number.
By their numbers in this assay, from the lowest: compounds 3, 2, 1 and 4 (each within the scatter of the next).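

In this assay, among these compounds, the step of a 1.5-fold higher number from compound 3 to compound 4 (0.17 log units; within the scatter) is the first measured change made in just one place, so it gives the first direct reading for this aromatic carbon, para to a large group. Trading methyl for trifluoromethyl, a group with more heavy atoms, leaves compound 4 indistinguishable from compound 3 on this read-out, so this swap alone gives no real difference in inhibition. No measurement of any property of these groups bears on this result.

From the compounds shown here alone, whether an amine or a carboxylic acid on the same aromatic carbon would give a step beyond the scatter remains open. Going by these compounds, it is also open whether an amide in place of the ester link, keeping the same aromatic ring, would shift the number more than this swap did.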